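Working notes: 2-hydroxyphenyl in place of 4-methylphenyl

The compounds below may be only part of what the source reports. "The series", "measured", "known", "first", "only" and "open" are said of these compounds alone.

compound 1 `CC1(C)[C@H]2CC[C@]1(C)N(Cc1cn(-c3ccccc3F)nn1)C(=O)C2`: 240 nM
compound 2 `Cc1ccc(-n2cc(CN3C(=O)C[C@@H]4CC[C@@]3(C)C4(C)C)nn2)cc1`: 400 nM

For the measured compounds named here, in a functional assay on A549 cells (Homo sapiens) for inhibition, read by MTT assay, with a stated time of 24 h (a higher number here means a weaker inhibitor, a lower number a stronger inhibitor), compound 2 gives 400 nM, a number within the scatter of the only other measured compound. The next compound is compound 3 `CC1(C)[C@H]2CC[C@]1(C)N(Cc1cn(-c3ccccc3O)nn1)C(=O)C2`, which carries 2-hydroxyphenyl in place of 4-methylphenyl on an aromatic nitrogen. Going by the values given here, one measured step bears on this change, at the same nitrogen: a 1.7-fold higher number from compound 1 to compound 2 (0.22 log units; within the scatter). Among the compounds with values here, that step shows no response beyond the scatter, but it covers only 2-fluorophenyl and 4-methylphenyl, and 2-hydroxyphenyl has no measured precedent. No step beyond the scatter is therefore expected in this assay, and no direction can be called with confidence. The estimated step is a 1.3-fold lower number from compound 2 to compound 3 (0.12 log units; within the scatter). Compound 3 is expected at 300 nM, with an estimated range of 100 nM to 900 nM.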

Compound 3, half-maximal inhibitory concentration: 230 nM
The estimate for compound 3 lay 1.3-fold (0.12 log units) above the measured number, within the range that was stated.
By their numbers in this assay, from the lowest: compounds 3, 1 and 2 (each within the scatter of the next).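

In this assay, the aromatic nitrogen also accepts 2-hydroxyphenyl, which brings the hydrogen-bond donor and acceptor counted for it, and the step stays within the scatter: a 1.7-fold lower number from compound 2 to compound 3 (0.24 log units; within the scatter). The new pair isolates a single exchange on an aromatic carbon, hydroxy in place of fluoro, and this step is also within the scatter: a 1.0-fold lower number from compound 1 to compound 3 (0.02 log units; within the scatter). Across compounds 1, 2 and 3, therefore, these three aryl groups are not separated by this assay, and no measured evidence bears on that result.

Going by these compounds, it remains open whether an aminophenyl or carboxyphenyl group, or a longer alkyl chain in place of the aryl ring, would give a step beyond the scatter. On these data alone, the effect of 4-hydroxyphenyl, with the hydroxy group placed elsewhere on the ring, also remains open.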